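Replacing the aryl group on the hydrazone carbon

The compounds below may be only part of what the source reports. "The series", "measured", "known", "first", "only" and "open" are said of these compounds alone.

Measured compounds:
- Compound 1 `CN(C)CCn1cnnc1-c1cc(Oc2ccc(NC(=O)N/N=C/c3ccc(Cl)cc3Cl)cc2F)ccn1`: 130 nM
- Compound 2 `CN(C)CCn1cnnc1-c1cc(Oc2ccc(NC(=O)N/N=C/c3ccccc3O[N+](=O)[O-])cc2F)ccn1`: 1270 nM

In a functional assay on NCI-H460 cells (Homo sapiens) for cytotoxicity, read by MTT assay, with a stated time of 72 h (a higher number here means a weaker inhibitor, a lower number a stronger inhibitor), compound 2 gives the higher of the two numbers; its nearest neighbour is compound 1, which differs only in the aryl group on the hydrazone carbon, and the step of a 9.8-fold higher number from compound 1 to compound 2 (0.99 log units; beyond the scatter) is beyond the scatter. Compound 3 `COc1cc(/C=N/NC(=O)Nc2ccc(Oc3ccnc(-c4nncn4CCN(C)C)c3)c(F)c2)cc(OC)c1OC` carries a further change at the same place: 3,4,5-trimethoxyphenyl in place of 2-(nitrooxy)phenyl on a carbon with a double bond to nitrogen. For the measured compounds named here, only that single aryl step bears on this change, and it was modest. For compound 3 in this assay a number near that of compound 2, or somewhat lower, is expected, giving a 2.1-fold lower number from compound 2 to compound 3 (0.33 log units; beyond the scatter). The estimate for compound 3 is 600 nM, within 150 nM to 2500 nM.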

Compound 3, half-maximal inhibitory concentration: 2770 nM
Compound 3: the middle estimate sits 4.6-fold (0.66 log units) below what was measured, and the stated range ends below it.
By their numbers in this assay, from the lowest: compound 1; then compound 2; then compound 3.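

In this assay, the step of a 2.2-fold higher number from compound 2 to compound 3 (0.34 log units; beyond the scatter) and the step of a 21-fold higher number from compound 1 to compound 3 (1.33 log units; beyond the scatter) show that this position on the hydrazone carbon continues to separate the compounds. Among the three aryl groups shown, 2,4-dichlorophenyl gives the lowest number and 3,4,5-trimethoxyphenyl the highest, although 3,4,5-trimethoxyphenyl and 2-(nitrooxy)phenyl have the same count of hydrogen-bond acceptors. Nothing given here accounts for this order. The compounds shown leave open where an unsubstituted phenyl, a single chlorine or a single methoxy group would fall, and how an aryl group bearing an amine or a carboxylic acid would compare.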